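Dropping the Chloro from a Potent Acylhydrazone

A few compounds are considered here, and "the series" means these few. Any claim that something is new, unique, unknown or untested is made for them only; others in the source may bear on it.

Compound 1, `COc1ccc(OC)c(/C=C/c2nnc(Nc3ccc(Cl)cc3)o2)c1`: in a functional assay on MDA-MB-435 cells (Homo sapiens) for antiproliferative activity, read by sulforhodamine B assay, with a stated time of 48 h (on this read-out lower numbers stand for stronger inhibition of growth and higher numbers for weaker inhibition of growth), compound 1 gives 37000 nM
Compound 2, `COc1ccc(OC)c(/C=C/C(=O)N/N=C/c2ccc(Cl)cc2)c1`: in this assay compound 2 gives 31.1 nM

On these two numbers compound 2 stands lowest, and its gap to compound 1 lies far beyond the usual scatter. Compound 3, `COc1ccc(OC)c(/C=C/C(=O)N/N=C/c2ccccc2)c1`, differs from compound 2 in one place: hydrogen in place of chloro on an aromatic carbon. For the measured compounds named here, no measured pair shows this change, so its effect is not known from these data. The step is expected to be small, a 2.6-fold higher number from compound 2 to compound 3 (0.41 log units; beyond the scatter), leaning toward a slightly higher number but possibly within the scatter. Compound 3 is estimated at 80 nM, with a range from 20 nM to 400 nM.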

Compound 3, concentration for 50% growth inhibition: 283 nM
The estimate for compound 3 lay 3.5-fold (0.55 log units) below the measured number, and the stated range covers the measured number.
By their numbers in this assay, from the lowest: compound 2; then compound 3; then compound 1.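

Taking the chloro off the 4-chlorophenyl group gives a 9.1-fold higher number from compound 2 to compound 3 (0.96 log units; beyond the scatter) in this assay, so this single atom on the ring carries a real share of the potency of compound 2. The parent phenyl compound still stays far more potent than compound 1 on the printed values. Nothing here explains why this one atom matters so much. On these data alone, whether fluoro, bromo, methyl, methoxy or an amine at this place would match the chloro remains open. So does whether the same change would have a similar effect on the core of compound 1.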